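Extending the Aryl Sulfonamide of a Quinazoline Series

This account rests on a few compounds, and the source may have more. Where it says the series, first, only, none or still open, it means among the compounds named here.

Of the compounds shown here, three sharing one core have been tested in a functional assay on PC-3 cells (Homo sapiens) for inhibition; a higher number here means a weaker inhibitor, a lower number a stronger inhibitor. Compound 1 `COc1cc2nc(N3CCN(S(=O)(=O)c4cccc([N+](=O)[O-])c4)CC3)nc(N)c2cc1OC` gives 32000 nM, compound 2 `COc1cc2nc(N3CCN(S(=O)(=O)c4ccc(C)cc4)CC3)nc(N)c2cc1OC` gives 30000 nM, and compound 3 `COc1cc2nc(N3CCN(S(=O)(=O)c4ccc5ccccc5c4)CC3)nc(N)c2cc1OC` gives 15000 nM. Compound 2 stands second highest of the three, close to compound 1 and furthest from compound 3. The untested compound 4 `CCCCc1ccc(-c2ccc(S(=O)(=O)N3CCN(c4nc(N)c5cc(OC)c(OC)cc5n4)CC3)cc2)cc1` differs from compound 2 as follows: 4-butylphenyl in place of methyl on an aromatic carbon. The most telling prior step is the enlargement of the aryl group on the sulfonyl sulfur, which gave a 2.0-fold lower number from compound 2 to compound 3 (0.30 log units; within the scatter) and a 2.1-fold lower number from compound 1 to compound 3 (0.33 log units; beyond the scatter), while swapping one small substituent for another gave only a 1.1-fold lower number from compound 1 to compound 2 (0.03 log units; within the scatter). A larger aromatic group therefore seems to lower the number somewhat, though never far. For compound 4 the estimated outcome is a 2.0-fold lower number from compound 2 to compound 4 (0.30 log units; within the scatter), a small improvement at most. Compound 4 is expected to give 15000 nM in this assay, within a range of 5000 nM to 45000 nM.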

Compound 4, half-maximal inhibitory concentration: 3400 nM
Beside the measured number, compound 4's estimate is 4.4-fold (0.64 log units) above it; the measured number lies below the stated range.
By their numbers in this assay, from the lowest: compound 4; then compounds 3, 2 and 1 (each within the scatter of the next, the first and the last beyond it).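

In this assay, 4-butylphenyl in place of methyl on an aromatic carbon gave an 8.8-fold lower number from compound 2 to compound 4 (0.95 log units; beyond the scatter), a far larger step than any earlier change of the group on the sulfonyl sulfur. This position, para to a large group, therefore accepts a much bigger substituent, with 10 heavy atoms entering where 1 leaves, and the inhibitor gets stronger rather than weaker. No measurement here bears on why the number falls.

Going by these compounds alone, the single step changes two things at once, adding both an aromatic ring and a butyl chain, so it cannot show which of them matters or whether both are needed. A plain phenyl at this place would begin to separate the two, while a longer chain such as hexyl, or an amine at the end of the chain, would test how far the trend runs.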